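Chloro Additions on Two Cores Against Liver Cancer Cells

The source may report more compounds than this note shows. Statements on the series, on what has been measured and on what is new or still open speak of the compounds shown alone.

Compound 1 `C=C(c1ccc(Cl)c(Cl)c1Cl)C1COC2(CCCC2)OO1` gives 8450 nM in a functional assay on HepG2 cells (Homo sapiens) for inhibition, read by MTT assay, with a stated time of 72 h; a lower number here means a stronger inhibitor, a higher number a weaker inhibitor. Compound 2 `C=C(c1ccc(Cl)cc1Cl)C1COC2(CCCC2)OO1` gives 15700 nM in this assay. Compound 3 `C=C(c1ccc(Cl)c(Cl)c1)C1COC(C)(C)OO1` gives only a limit, > 100000 nM, in this assay.

Compound 2 and compound 1 share one core and differ by chloro in place of hydrogen on an aromatic carbon; the step was a 1.9-fold lower number from compound 2 to compound 1 (0.27 log units; within the scatter). Compound 3 carries a second core; how the two cores differ is not broken down here. Compound 4 `C=C(c1ccc(Cl)c(Cl)c1Cl)C1COC(C)(C)OO1` is compound 3 with chloro in place of hydrogen on an aromatic carbon. This is the same kind of change as from compound 2 to compound 1, though there the new chloro was ortho to two chloro groups and meta to a large group, while here it is ortho to a chloro group, ortho to a large group and meta to a chloro group. Because compound 3 sits at the limit of > 100000 nM in this assay, at which 1 of the 3 values shown sits, and the matching earlier step stayed within the scatter, compound 4 is expected to land near 80000 nM in this assay, a step of an at least 1.2-fold lower number from compound 3 to compound 4 (0.09 log units; that floor lies within the scatter), and may well return as a limit again.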

Compound 4, half-maximal inhibitory concentration: 27300 nM
The estimate for compound 4 lay 2.9-fold (0.47 log units) above the measured number; measured number outside the range, below it.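

In this assay, chloro in place of hydrogen on an aromatic carbon of the second core gave an at least 3.6-fold lower number from compound 3 to compound 4 (0.56 log units; beyond the scatter). As far as these compounds go, compound 3 has only a limit, > 100000 nM, so the true size of this step remains unknown. The change has now been read on two cores, which shows that it can be compared across them but does not show that its size carries over from one core to the other: the same change on two cores in this assay, a 1.9-fold lower number (0.27 log units; within the scatter) from compound 2 to compound 1 and an at least 3.6-fold lower number (0.56 log units; beyond the scatter) from compound 3 to compound 4; the limit leaves it open whether they differ

The compounds shown leave open whether a group other than chloro, such as a methoxy group or an amine, would give a step of similar size at this place. They also leave open whether either core would respond to such a group in the same way.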